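Fluoro to hydroxy on the side chain: compound 4

This account rests on a few compounds, and the source may have more. Where it says the series, first, only, none or still open, it means among the compounds named here.

Compound 1 `COc1cc(C(c2ccc(O)c(OC)c2)[C@H](C)[C@@H](C)CF)ccc1O` gives 45000 nM in a functional assay on HL-60 cells (Homo sapiens) for cytotoxicity, read by WST assay, with a stated time of 48 h; on this read-out lower numbers stand for stronger inhibition and higher numbers for weaker inhibition.
Compound 2 `COc1cc(C(c2ccc(O)c(OC)c2)[C@H](CC(C)C)C(C)C)ccc1O` gives 9600 nM in this assay.
Compound 3 `COc1cc(C(c2ccc(O)c(OC)c2)[C@H](C)[C@@H](C)CO)ccc1O` gives > 100000 nM in this assay, which is a limit of the assay and not a number.

Compound 1 holds the highest of the two plain numbers; compound 2 is its nearest neighbour and shows a 4.7-fold lower number from compound 1 to compound 2 (0.67 log units; beyond the scatter). Compound 3 reaches (the limit of > 100000 nM in this assay, at which 1 of the 3 values shown sits), so from compound 1 to compound 3 the change reads an at least 2.2-fold higher number from compound 1 to compound 3 (0.34 log units; beyond the scatter), and from compound 2 to compound 3 it reads an at least 10-fold higher number from compound 2 to compound 3 (1.01 log units; beyond the scatter).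

The unmeasured compound 4 `COc1cc(C(c2ccc(O)c(OC)c2)[C@H](C)[C@H](C)CO)ccc1O` differs from compound 1 in one place: 1-(hydroxymethyl)ethyl in place of 1-(fluoromethyl)ethyl on a saturated chain carbon bound to two saturated chain carbons. Cut one bond further out, the same change is the one that separates compound 1 from compound 3, and compound 4 differs from compound 3 only in the defined stereocentre of the entering group. The step from compound 1 to compound 3 is the one that bears directly on it, and it went upward beyond the scatter to the limit of the assay. Compound 4 is therefore expected to move in the same direction, with a 3.3-fold higher number from compound 1 to compound 4 (0.52 log units; beyond the scatter) as the estimated step, and most likely to return only a limit as compound 3 did. The estimate for compound 4 is 150000 nM, within a range from 60000 nM to 400000 nM.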

Compound 4, half-maximal inhibitory concentration: > 100000 nM
Compound 4 ended at the assay's limit; the forecaster's own chance of this, stated with the estimate: 65%; the middle value lies beyond the limit too.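

With the stereocentre at the saturated chain carbon drawn the other way, 1-(hydroxymethyl)ethyl in place of 1-(fluoromethyl)ethyl still raises the number in this assay, with an at least 2.2-fold higher number from compound 1 to compound 4 (0.34 log units; beyond the scatter), so the upward step seen earlier is not confined to the configuration of compound 3. The comparison with the larger side chain also holds for this configuration, with an at least 10-fold higher number from compound 2 to compound 4 (1.01 log units; beyond the scatter). Compound 4 gives > 100000 nM, which is a limit of the assay and not a number, and the step between the two hydroxy compounds cannot be read, so this position shows no readable preference for either configuration: the fact that compounds 3 and 4 differ only in the configuration as drawn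

The compounds shown leave open how far beyond the limit the two hydroxy compounds lie, and so whether configuration matters at all once the hydroxy group is present: the limit of > 100000 nM in this assay, at which 2 of the 4 values shown sit. They also leave open how the fluoro group of compound 1 would read with the stereocentre inverted, and how an amine or a methoxy group would read in place of the hydroxy group at the end of this chain.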